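Carbonyl side-chain substituents on the shared core

A few compounds are considered here, and "the series" means these few. Any claim that something is new, unique, unknown or untested is made for them only; others in the source may bear on it.

Measured so far in a functional assay on the whole organism for inhibition, with Cavia porcellus as the target; on this read-out lower numbers stand for an effect already at smaller amounts and higher numbers for an effect only at larger amounts of compound:
compound 1 `CCOC(=O)CC(=O)N1CCSC1COc1ccccc1OC`: 21 mg/kg
compound 2 `COc1ccccc1OCC1SCCN1C(=O)CNC(C)=O`: 40 mg/kg
compound 3 `COc1ccccc1OCC1SCCN1C(C)=O`: 46 mg/kg

Compound 3 carries the highest number of the three. Its gap to compound 2 is within the scatter, so these two cannot be ordered; its gap to compound 1 is beyond the scatter and modest, a 2.2-fold higher number from compound 1 to compound 3 (0.34 log units; beyond the scatter).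

Compound 4 `COc1ccccc1OCC1SCCN1C(=O)CC(C)=O` is the next member. It differs from compound 3 in one place: acetyl in place of hydrogen on a saturated chain carbon bound to a carbonyl carbon.

For the measured compounds named here, two measured steps bear on this change, both at the same place on the saturated chain carbon bound to a carbonyl carbon. Removing ethoxycarbonyl to hydrogen gave a 2.2-fold higher number from compound 1 to compound 3 (0.34 log units; beyond the scatter); removing acetamido to hydrogen gave a 1.2-fold higher number from compound 2 to compound 3 (0.06 log units; within the scatter). Acetyl, like ethoxycarbonyl, brings a carbonyl and an acceptor to that carbon, so the closer precedent is compound 1, and the step from compound 3 to compound 4 is expected to run the other way round, toward a lower number, roughly a 1.6-fold lower number from compound 3 to compound 4 (0.22 log units; within the scatter), with the compound 2 result keeping the expectation to a modest size. Compound 4 is therefore estimated at 28 mg/kg in this assay, within 14 mg/kg to 56 mg/kg.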

Compound 4, dose for half-maximal effect: 30 mg/kg
Compound 4: the middle estimate sits 1.1-fold (0.03 log units) below what was measured; low and high end bracket the measured number.
By their numbers in this assay, from the lowest: compounds 1, 4, 2 and 3 (each within the scatter of the next, the first and the last beyond it).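

In this assay, acetyl in place of hydrogen on a saturated chain carbon bound to a carbonyl carbon gives a step that stays within the scatter (a 1.5-fold lower number from compound 3 to compound 4 (0.19 log units; within the scatter)), so this change alone does not separate the two compounds. The comparisons with the other substituted side chains also stay within the scatter: acetyl in place of acetamido on that carbon (a 1.3-fold lower number from compound 2 to compound 4 (0.12 log units; within the scatter)) and methyl in place of ethoxy on a carbonyl carbon (a 1.4-fold higher number from compound 1 to compound 4 (0.15 log units; within the scatter)) order none of these pairs. Compound 4 therefore stands within the scatter of all three earlier compounds, which leaves the gap between compound 1 and compound 3 as the only one beyond the scatter, and nothing available accounts for this picture.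

Still open, on these data alone, is whether a primary amine, a carboxylic acid or a longer chain on the saturated chain carbon bound to a carbonyl carbon would give a number beyond the scatter of compound 4. All the compounds shown keep the shared core intact, so they leave open how much a change elsewhere on it would matter in this assay on this read-out.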